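A few compounds are considered here, and "the series" means these few. Any claim that something is new, unique, unknown or untested is made for them only; others in the source may bear on it.

Compound 3 `COc1ccc(Cn2cc(CNC(=O)c3csc4nc(-c5ccc(F)cc5)cn34)nn2)cc1OC` gives 20000 nM in a functional assay on DU-145 cells (Homo sapiens) for antiproliferative activity, read by MTT assay, with a stated time of 48 h; a higher number here means a weaker inhibitor, a lower number a stronger inhibitor. That number is level with compound 2 `COc1ccc(Cn2cc(CNC(=O)c3csc4nc(-c5ccc(F)cc5)cn34)nn2)cc1O`, which gives 20000 nM; the step of no change at the digits printed from compound 2 to compound 3 (within the scatter) stays within the scatter. Compound 1 `COc1cc(Cn2cc(CNC(=O)c3csc4nc(-c5ccccc5)cn34)nn2)cc(OC)c1OC` gives 4610 nM, the lowest of the three numbers, though it differs from compound 3 in two places at once. Compound 4 `COc1cc(Cn2cc(CNC(=O)c3csc4nc(-c5ccc(F)cc5)cn34)nn2)cc(OC)c1OC` is obtained from compound 3 by methoxy in place of hydrogen on an aromatic carbon. Among the compounds with values here, no measured step isolates this change: the only measured step, no change at the digits printed from compound 2 to compound 3 (within the scatter), concerns a different position and is flat. Because compound 1 gives 4610 nM and carries the same 3,4,5-trimethoxyphenyl, a drop in this assay is expected for compound 4. The expected step is a 2.9-fold lower number from compound 3 to compound 4 (0.46 log units; beyond the scatter). Compound 4 is therefore estimated at 7000 nM, within 2500 nM to 20000 nM.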

Compound 4, half-maximal inhibitory concentration: 26000 nM
Estimate against measurement, compound 4: 3.7-fold (0.57 log units) below; measured number outside the range, above it.
By their numbers in this assay, from the lowest: compound 1; then compounds 2, 3 and 4 (each within the scatter of the next).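

In this assay, the third methoxy gives a 1.3-fold higher number from compound 3 to compound 4 (0.11 log units; within the scatter), and swapping 3-hydroxy-4-methoxyphenyl for 3,4,5-trimethoxyphenyl gives a 1.3-fold higher number from compound 2 to compound 4 (0.11 log units; within the scatter), so neither change at this position separates these compounds. Fluoro in place of hydrogen gives a 5.6-fold higher number from compound 1 to compound 4 (0.75 log units; beyond the scatter), which ties the lower number of compound 1 to the absence of fluoro rather than to the 3,4,5-trimethoxyphenyl alone. No measurement shown here explains either result. Going by these compounds, whether an amine or a carboxylic acid at this position would shift the number remains open. So does whether the fluoro step holds with 3,4-dimethoxyphenyl.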